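This account rests on a few compounds, and the source may have more. Where it says the series, first, only, none or still open, it means among the compounds named here.

The measured compounds are:
compound 1, `O=C1CC(c2ccccc2Cl)n2ncnc2N1`, giving 25.5 mg/kg in a functional assay on the whole organism (strain Kunming) with Mus musculus as the target; on this read-out lower numbers stand for an effect already at smaller amounts and higher numbers for an effect only at larger amounts of compound;
compound 2, `O=C1CC(c2ccccc2Br)n2ncnc2N1`, giving 19.7 mg/kg;
compound 3, `O=C1CC(c2ccccc2Cl)n2nccc2N1`, giving 63.4 mg/kg.

Compound 2 differs from compound 1 by bromo in place of chloro on an aromatic carbon, and this change made a 1.3-fold lower number from compound 1 to compound 2 (0.11 log units; within the scatter). Compound 3 carries the same chloro group as compound 1 but on a different core; the difference between the two cores is not broken down here. In this assay compound 3 stands highest of the three numbers, with compound 1 nearest and compound 2 furthest, both of those gaps lying beyond the scatter.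

Compound 4, `O=C1CC(c2ccccc2Br)n2nccc2N1`, has not yet been measured. It differs from compound 3 by bromo in place of chloro on an aromatic carbon, which is the same change as that from compound 1 to compound 2, at the same kind of place. Compound 4 is expected to show a step of a 1.3-fold lower number from compound 3 to compound 4 (0.11 log units; within the scatter) in this assay, because the same change earlier gave a 1.3-fold lower number from compound 1 to compound 2 (0.11 log units; within the scatter). Compound 4 is therefore estimated at 49 mg/kg, with a likely range from 28 mg/kg to 85 mg/kg.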

Compound 4, dose for half-maximal effect: 39.4 mg/kg
Compound 4: middle estimate off by 1.2-fold (0.09 log units), on the high side, within the range that was stated.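

In this assay, putting bromo in place of chloro on the core of compound 3 gave a 1.6-fold lower number from compound 3 to compound 4 (0.21 log units; within the scatter), and this step can be set beside the one seen earlier on the core of compound 1: the same change on two cores in this assay, a 1.3-fold lower number (0.11 log units; within the scatter) from compound 1 to compound 2 and a 1.6-fold lower number (0.21 log units; within the scatter) from compound 3 to compound 4, 1.2-fold (0.09 log units) apart, within the scatter of two such steps. Within these two pairs, then, the change carries from one core to the other with no difference in step size that can be told apart from the scatter. This does not separate bromo from chloro, as each step lies within the scatter on its own, and two pairs say nothing about any further core or about this change at another place.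

The compounds shown carry only chloro or bromo on the six-membered aromatic ring, so it remains open how fluoro, a methoxy group, an amine or a carboxylic acid would read out at that place. Also open, as far as these compounds go, is what a longer chain on the core would do in either series.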